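Taking the remaining methyl off compound 3

The compounds below may be only part of what the source reports. "The series", "measured", "known", "first", "only" and "open" are said of these compounds alone.

In a functional assay on cells (Tumor Cell line, Homo sapiens) for cytotoxicity (a higher number here means a weaker inhibitor of growth, a lower number a stronger inhibitor of growth), compound 1 (`COc1cccc(-c2cc(O)c3c(C)cc(C)nc3n2)c1`) gives 646 nM and compound 2 (`COc1cccc(-c2cc(O)c3cc(C)cnc3n2)c1`) gives 95.5 nM while compound 3 (`COc1cccc(-c2cc(O)c3c(C)ccnc3n2)c1`) gives 58.9 nM and so stands within the scatter of compound 2. Compound 4 (`COc1cccc(-c2cc(O)c3cccnc3n2)c1`) carries hydrogen in place of methyl on an aromatic carbon opposite the ring nitrogen. One measured step is of this kind (an 11-fold lower number from compound 1 to compound 3 (1.04 log units; beyond the scatter)) and it was large, but it took away a different methyl, so it gives little guidance at this place. A modest change is therefore expected, and its direction is uncertain. The expected step is a 1.7-fold higher number from compound 3 to compound 4 (0.23 log units; within the scatter) and it remains only an estimate. For compound 4 the estimated value is 100 nM with an expected range from 30 nM to 350 nM in this assay here.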

Compound 4, concentration for 50% growth inhibition: 135 nM
Compound 4: the middle estimate sits 1.4-fold (0.13 log units) below what was measured; low and high end bracket the measured number.
By their numbers in this assay, from the lowest: compounds 3, 2 and 4 (each within the scatter of the next, the first and the last beyond it); then compound 1.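

In this assay, taking off the methyl opposite the ring nitrogen gives a 2.3-fold higher number from compound 3 to compound 4 (0.36 log units; beyond the scatter), so the loss of a methyl can also raise the number, whereas the earlier step lowered it. Loss of the methyl at the other place gives a 1.4-fold higher number from compound 2 to compound 4 (0.15 log units; within the scatter), a step within the scatter. The change therefore has no single effect across the shared core: the same change on two cores in this assay, an 11-fold lower number (1.04 log units; beyond the scatter) from compound 1 to compound 3 and a 1.4-fold higher number (0.15 log units; within the scatter) from compound 2 to compound 4, 16-fold (1.19 log units) apart, beyond the scatter of two such steps

On these data alone, whether an ethyl group, a chlorine atom or an amine at the place opposite the ring nitrogen would lower the number further remains open.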